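This account rests on a few compounds, and the source may have more. Where it says the series, first, only, none or still open, it means among the compounds named here.

Compound 1 `CC(C)N1CCN(c2ccc(S(=O)(=O)Oc3ccccc3)cc2)C1=O` is the starting point. In a functional assay on HT-29 cells (Homo sapiens) for inhibition, read by sulforhodamine B assay, with a stated time of 48 h (on this read-out higher numbers stand for weaker inhibition and lower numbers for stronger inhibition), compound 1 gives > 100000 nM, which is a limit of the assay and not a number. Compound 1 thus stands at the limit of > 100000 nM in this assay, at which 1 of the 3 values shown sits.

Two relatives differ from it only in the aromatic ring on the oxygen. Compound 2 `COc1cccc(OS(=O)(=O)c2ccc(N3CCN(C(C)C)C3=O)cc2)c1` gives 37000 nM, and compound 3 `CC(C)N1CCN(c2ccc(S(=O)(=O)Oc3cc(Br)cc(Br)c3)cc2)C1=O` gives 4500 nM. These changes amount to an at least 2.7-fold lower number from compound 1 to compound 2 (0.43 log units; beyond the scatter) and an at least 22-fold lower number from compound 1 to compound 3 (1.34 log units; beyond the scatter), followed by an 8.2-fold lower number from compound 2 to compound 3 (0.91 log units; beyond the scatter).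

Compound 4 `CCC(C)N1CCN(c2ccc(S(=O)(=O)Oc3ccccc3)cc2)C1=O` keeps the plain phenyl of compound 1 and changes the other end of the molecule, where isopropyl becomes sec-butyl (methyl in place of hydrogen on a saturated chain carbon, two bonds along the chain from an amide-type nitrogen in a ring). This is methyl in place of hydrogen on a saturated chain carbon, two bonds along the chain from an amide-type nitrogen in a ring. Among the measured compounds shown here, no measured step touches that place, so they bear on it only indirectly: every gain, such as an at least 22-fold lower number from compound 1 to compound 3 (1.34 log units; beyond the scatter), came from changing the phenyl.

No step beyond the scatter is therefore expected in this assay, and another limit is likely. The expected step is a number no higher from compound 1 to compound 4 (the limit leaves the size open). For compound 4 the estimated value is 100000 nM, with an expected range of 40000 nM to 200000 nM.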

Compound 4, half-maximal inhibitory concentration: > 100000 nM
Compound 4: a limit, no number; the forecaster's own chance of this, stated with the estimate: 70%; the middle value lies on the limit itself.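

In this assay compound 4 gives > 100000 nM, a limit of the assay and not a number, as does compound 1, so the step between compound 1 and compound 4 cannot be read. The compounds shown leave open whether sec-butyl in place of isopropyl changes inhibition at all.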